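This account rests on a few compounds, and the source may have more. Where it says the series, first, only, none or still open, it means among the compounds named here.

Compound 2 `Cc1ccc(-c2nccnc2OC2CN(c3ccc4ccccc4n3)C2)cc1` stands at the bottom of what a physicochemical assay for solubility, in phosphate buffer, at pH 7.4 (a higher number here means a more soluble compound, a lower number a less soluble compound), reports: in this assay compound 2 gives < 1000 nM, which is a limit of the assay and not a number (the limit of < 1000 nM in this assay, at which 1 of the 2 values shown sits). Compound 3 `CS(=O)(=O)N1CCC(c2nccnc2OC2CN(c3ccc4ccccc4n3)C2)CC1` carries 1-(methylsulfonyl)piperidin-4-yl in place of 4-methylphenyl on an aromatic carbon. Within the data shown here, one measured step bears on this change, and it runs the other way: compound 1 `OC1CCN(c2nccnc2OC2CN(c3ccc4ccccc4n3)C2)CC1` gives 99000 nM, and an at least 99-fold lower number from compound 1 to compound 2 (1.99 log units; beyond the scatter). Going back from an aromatic group to a saturated ring, a large rise in this assay is expected for compound 3, roughly an at least 20-fold higher number from compound 2 to compound 3 (1.30 log units; beyond the scatter). Compound 3 is therefore estimated at 20000 nM, between 3000 nM and 90000 nM.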

Compound 3, solubility: 181000 nM
Compound 3: the middle estimate sits 9.1-fold (0.96 log units) below what was measured; the measured number lies above the stated range.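

In this assay, putting 1-(methylsulfonyl)piperidin-4-yl in place of 4-methylphenyl on this aromatic carbon gives an at least 180-fold higher number from compound 2 to compound 3 (2.25 log units; beyond the scatter). Compound 2 gives a limit of the assay and not a number: the limit of < 1000 nM in this assay, at which 1 of the 3 values shown sits. The two saturated rings cannot be told apart at this position, with a 1.8-fold higher number from compound 1 to compound 3 (0.26 log units; within the scatter).

With 4-methylphenyl as the only aromatic group shown, it remains open whether a pyridine would also sit at the low end. On these data alone, how an unsubstituted piperidine or a carboxylic acid would read at this position also remains open.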